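A few compounds are considered here, and "the series" means these few. Any claim that something is new, unique, unknown or untested is made for them only; others in the source may bear on it.

Compound 1 `N#CC1=C(N)Oc2c(c3nc4ccccc4nc3c3ccccc23)C12C(=O)N(Cc1cnnn1-c1ccc(N)cc1)c1ccccc12` and compound 2 `CC(=O)Nc1ccc(-n2nncc2CN2C(=O)C3(C(C#N)=C(N)Oc4c(N)cc5nc6ccccc6nc5c43)c3ccccc32)cc1` were both tested in an ADME assay on L02 cells (Homo sapiens) for antiproliferative activity, read by MTT assay, with a stated time of 48 h; on this read-out lower numbers stand for stronger inhibition and higher numbers for weaker inhibition. In this assay compound 1 reached only the limit of > 50000 nM. Compound 2 likewise reached only the limit of > 50000 nM. Among the compounds with values here, both values sit at the limit of > 50000 nM in this assay, at which 2 of the 2 values shown sit, and no step between them can be sized. Compound 3 `N#CC1=C(N)Oc2c(N)cc3nc4ccccc4nc3c2C12C(=O)N(Cc1cnnn1-c1cc(Cl)ccc1Cl)c1ccccc12` carries 2,5-dichlorophenyl in place of 4-acetamidophenyl on an aromatic nitrogen. Within the data shown here, compound 2 gave no number, so no measured step exists to build on; the expected step that the limit leaves unreadable from compound 2 to compound 3 is none beyond the scatter. Compound 3 is therefore estimated to give 60000 nM in this assay, within 20000 nM to 200000 nM, most likely reported again only as a limit.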

Compound 3, half-maximal inhibitory concentration: > 50000 nM
Compound 3 gave a limit, no number; the forecaster's own chance of this, stated with the estimate: 80%; the middle value does not contradict the limit.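

Within the data shown here, compound 3, like compound 2, gave only a limit, so no step between them can be read: the limit of > 50000 nM in this assay, at which 3 of the 3 values shown sit.

In this assay the compounds shown leave open whether the group on the aromatic nitrogen changes the result at all.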